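Adding a hydroxy group to compound 2: expected potency

The compounds below may be only part of what the source reports. "The series", "measured", "known", "first", "only" and "open" are said of these compounds alone.

The series shares one core, carrying a nitro-substituted benzylamine. In an assay for inhibition of Indoleamine 2,3-dioxygenase 1 (Homo sapiens), with stated times of 10 min and 60 min (a lower number here means a stronger inhibitor, a higher number a weaker inhibitor), compound 1 `O=[N+]([O-])c1ccccc1CNc1cc(C(F)(F)F)cc2[nH]ncc12` gives 14000 nM. Compound 2 `O=[N+]([O-])c1ccccc1CNc1cc(Br)cc2[nH]ncc12` gives 8040 nM in this assay, the lowest of the two numbers shown; the step of a 1.7-fold lower number from compound 1 to compound 2 (0.24 log units; within the scatter) places compound 2 closest to compound 1, within the scatter. Within the data shown here, compound 3 `CC(C)n1ncc2c(NCc3ccccc3[N+](=O)[O-])cc(C(F)(F)F)cc21` sits at a limit of this assay, > 100000 nM, which is the only limit among the values shown (the limit of > 100000 nM in this assay, at which 1 of the 3 values shown sits). Among the measured compounds shown here, the step of an at least 7.1-fold higher number from compound 1 to compound 3 (0.85 log units; beyond the scatter) is the single change on the core that moves the number beyond the scatter.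

Compound 4 `O=[N+]([O-])c1ccc(O)cc1CNc1cc(Br)cc2[nH]ncc12` differs from compound 2 by a single change, (hydroxy in place of hydrogen on an aromatic carbon), at the ring bearing the nitro group. Neither measured step concerns that ring: one exchanges a substituent on the core, the other adds isopropyl on an aromatic nitrogen. No measured evidence therefore speaks to this change, and the expectation is a step no larger than the scatter in this assay, in no fixed direction.

Compound 4 is expected to give about 8000 nM in this assay, between 2500 nM and 25000 nM. That estimate corresponds to a step of a 1.0-fold lower number from compound 2 to compound 4 (0.00 log units; within the scatter) from compound 2, expected to lie within the scatter.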

Compound 4, half-maximal inhibitory concentration: 910 nM
Estimate against measurement, compound 4: 8.8-fold (0.94 log units) above, and the stated range ends above it.
By their numbers in this assay, from the lowest: compound 4; then compounds 2 and 1 (each within the scatter of the next). At a limit, above all of these: compound 3.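

Among these compounds, the ring bearing the nitro group, which no earlier step touched, responds in this assay: the hydroxy group gives an 8.8-fold lower number from compound 2 to compound 4 (0.95 log units; beyond the scatter). Of the steps shown, this is the first to lower the number beyond the scatter; the change on the core gave only a 1.7-fold lower number from compound 1 to compound 2 (0.24 log units; within the scatter), and the isopropyl group on the aromatic nitrogen went the other way, with an at least 7.1-fold higher number from compound 1 to compound 3 (0.85 log units; beyond the scatter). The position para to a nitro group and meta to a large group therefore tolerates a substituent, and a single added oxygen there is enough to move the number, whereas nothing shown gives a cause for this step.

Open, from the compounds shown here alone, is whether the gain belongs to the hydroxy group as such, which a methoxy group, an amine or a carboxylic acid at the same place would help to settle. Also open, going by these compounds, is whether the hydroxy group gives a similar step on the trifluoromethyl core of compound 1, as compound 4 carries bromo and the step has been read on that background alone.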